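A few compounds are considered here, and "the series" means these few. Any claim that something is new, unique, unknown or untested is made for them only; others in the source may bear on it.

Compound 1 `Cc1ccc(NC(=O)CCN(Cc2ccc(C(=O)NO)cc2)C(=O)c2ccc(N(C)C)cc2)cc1`: 330 nM
Compound 2 `O=C(CCN(Cc1ccc(C(=O)NO)cc1)C(=O)c1ccccc1)NCc1ccccc1`: 5940 nM
Compound 3 `COc1cc(OC)cc(C(=O)N(CCC(=O)NCc2ccccc2)Cc2ccc(C(=O)NO)cc2)c1`: 14700 nM

In a functional assay on G55T2 cells (Homo sapiens) for antiproliferative activity, read by WST assay, with a stated time of 72 h (a higher number here means a weaker inhibitor, a lower number a stronger inhibitor), compound 3 gives the highest of the three numbers; its nearest neighbour is compound 2, and the step from phenyl to 3,5-dimethoxyphenyl is a 2.5-fold higher number from compound 2 to compound 3 (0.39 log units; beyond the scatter). Compound 4 `CN(C)c1ccc(C(=O)N(CCC(=O)NCc2ccccc2)Cc2ccc(C(=O)NO)cc2)cc1` differs from compound 3 in one place: 4-(dimethylamino)phenyl in place of 3,5-dimethoxyphenyl on a carbonyl carbon. Among the compounds with values here, no measured step shows this exact exchange, but compound 1, which carries the 4-(dimethylamino)phenyl on its carbonyl with a different amide part, gives 330 nM, far below compound 3. Since the 3,5-dimethoxyphenyl was the worst of the aryl groups seen, compound 4 is expected to move downward in this assay by a 9.8-fold lower number from compound 3 to compound 4 (0.99 log units; beyond the scatter), estimated at 1500 nM with a range of 400 nM to 6000 nM.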

Compound 4, half-maximal inhibitory concentration: 1150 nM
The estimate for compound 4 lay 1.3-fold (0.12 log units) above the measured number; measured number inside the range.
By their numbers in this assay, from the lowest: compound 1; then compound 4; then compound 2; then compound 3.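

In this assay, with the benzyl amide held fixed, the 4-(dimethylamino)phenyl on the carbonyl carbon improves on the 3,5-dimethoxyphenyl (a 13-fold lower number from compound 3 to compound 4 (1.11 log units; beyond the scatter)) and also on plain phenyl (a 5.2-fold lower number from compound 2 to compound 4 (0.71 log units; beyond the scatter)). Substitution on this aryl ring can therefore move the number in either direction, since compound 3 goes up from phenyl and compound 4 goes down. With the same aryl group, the amide part matters too (a 3.5-fold higher number from compound 1 to compound 4 (0.54 log units; beyond the scatter)). Nothing available explains these steps. Open, on these data alone, is how a morpholine or a carboxylic acid in place of the dimethylamino would read, and whether the 4-methylphenyl amide would lower the number for the other aryl groups.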